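The source may hold more compounds than are shown below. What is called first, only, known or untested is meant among the compounds shown, and "the series" means these compounds.

Compound 1 `CCOC(=O)c1cc(N2C(=O)C3=C(CCCC3)C2=O)ccc1Cl`: 1910 nM
Compound 2 `CCCOC(=O)c1cc(N2C(=O)C3=C(CCCC3)C2=O)ccc1Cl`: 1120 nM
Compound 3 `CC(C)OC(=O)c1cc(N2C(=O)C3=C(CCCC3)C2=O)ccc1Cl`: 1230 nM

These values come from a functional assay on the whole organism for inhibition, with Scenedesmus acutus as the target (a lower number here means a stronger inhibitor, a higher number a weaker inhibitor), and compound 3, at 1230 nM, lies within the scatter of both other compounds. Compound 4 `CCC(C)OC(=O)c1cc(N2C(=O)C3=C(CCCC3)C2=O)ccc1Cl` turns isopropyl into sec-butyl: methyl in place of hydrogen on a saturated chain carbon, two bonds along the chain from an oxygen next to a carbonyl group. The same kind of change, methyl in place of hydrogen on a saturated chain carbon, two bonds along the chain from an oxygen next to a carbonyl group, gave a 1.7-fold lower number from compound 1 to compound 2 (0.23 log units; within the scatter). The other two steps, a 1.6-fold lower number from compound 1 to compound 3 (0.19 log units; within the scatter) and a 1.1-fold higher number from compound 2 to compound 3 (0.04 log units; within the scatter), were also small. No step beyond the scatter is therefore expected in this assay, at most a slight drift to a lower number. The expected step is a 1.3-fold lower number from compound 3 to compound 4 (0.11 log units; within the scatter). For compound 4 the estimated value is 950 nM, with an expected range from 500 nM to 1800 nM.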

Compound 4, half-maximal inhibitory concentration: 1100 nM
The estimate for compound 4 lay 1.2-fold (0.06 log units) below the measured number, within the range that was stated.
By their numbers in this assay, from the lowest: compounds 4, 2, 3 and 1 (each within the scatter of the next).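

In this assay, a methyl on the saturated chain carbon two bonds along from the oxygen again gives only a small change on a second chain, with a 1.1-fold lower number from compound 3 to compound 4 (0.05 log units; within the scatter): the same change on two cores in this assay, a 1.7-fold lower number (0.23 log units; within the scatter) from compound 1 to compound 2 and a 1.1-fold lower number (0.05 log units; within the scatter) from compound 3 to compound 4, 1.5-fold (0.18 log units) apart, within the scatter of two such steps

A methyl on the chain carbon bound to that oxygen gives a 1.0-fold lower number from compound 2 to compound 4 (0.01 log units; within the scatter): the same change on two cores in this assay, a 1.6-fold lower number (0.19 log units; within the scatter) from compound 1 to compound 3 and a 1.0-fold lower number (0.01 log units; within the scatter) from compound 2 to compound 4, 1.5-fold (0.18 log units) apart, within the scatter of two such steps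

Ethyl in place of hydrogen on that carbon gives a 1.7-fold lower number from compound 1 to compound 4 (0.24 log units; within the scatter), so all four chains remain within the scatter of one another.

On these data alone, whether a much longer chain, a cyclohexyl ring or a terminal amine would move the number beyond the scatter remains open.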